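The source may hold more compounds than are shown below. What is called first, only, known or untested is meant among the compounds shown, and "the series" means these compounds.

Of the compounds shown here, three on the shared core have numbers so far in a functional assay on MIA PaCa-2 cells (Homo sapiens) for inhibition, read by MTT assay; on this read-out higher numbers stand for weaker inhibition and lower numbers for stronger inhibition. Compound 2 `O=C(Nc1ccc[n+]([O-])c1)c1cc2cnc(Nc3ccc(N4CCNCC4)cn3)nc2n1C1CCCC1` stands highest of the three at 125000 nM, which makes it the weakest inhibitor here, with both gaps beyond the scatter. The nearest number belongs to compound 1 `O=C(Nc1ccccc1)c1cc2cnc(Nc3ccccc3)nc2n1C1CCCC1` at 14000 nM, and the furthest to compound 3 `O=C(Nc1ccccc1)c1cc2cnc(Nc3ccc(N4CCNCC4)cn3)nc2n1Cc1ccccc1` at 3600 nM.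

Compound 4 `O=C(Nc1ccccc1Cl)c1cc2cnc(Nc3ccc(N4CCNCC4)cn3)nc2n1C1CCCC1` is still unmeasured and differs from compound 2 in one place: a group of 7 heavy atoms (6 carbon, 1 chlorine; one six-membered aromatic ring of carbon only) in place of a group of 7 heavy atoms (5 carbon, 1 nitrogen, 1 oxygen; one six-membered aromatic ring with 1 hetero atom), on an amide-type nitrogen. Going by the values given here, no measured pair differs in one place only, so no measured step isolates this change. In this assay a large step toward lower numbers, beyond the scatter, is nevertheless expected. That expectation rests on two compounds with an aromatic ring of carbon only on the amide-type nitrogen, as in compound 4: compound 1 at 14000 nM and compound 3 at 3600 nM. Both also differ from compound 2 elsewhere, so this support is indirect and the range is kept wide. The estimated change is a 21-fold lower number from compound 2 to compound 4 (1.32 log units; beyond the scatter), toward stronger inhibition. Compound 4 is estimated at 6000 nM, with an expected range of 1800 nM to 20000 nM.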

Compound 4, half-maximal inhibitory concentration: 2170 nM
Compound 4: the middle estimate sits 2.8-fold (0.44 log units) above what was measured, and the stated range covers the measured number.
By their numbers in this assay, from the lowest: compounds 4 and 3 (each within the scatter of the next); then compound 1; then compound 2.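

In this assay, going by these compounds alone, 2-chlorophenyl in place of the ring with one hetero atom on the amide-type nitrogen gives a 58-fold lower number from compound 2 to compound 4 (1.76 log units; beyond the scatter), toward stronger inhibition, and this is the first measured step that isolates a single place. The group on this amide-type nitrogen can therefore move the number well beyond the scatter on its own, even though both groups have the same count of heavy atoms and neither carries a net charge. No measurement of any property of these two groups bears on the step, so the result stands without an explanation.

The change removes the ring hetero atom and the oxygen and adds chlorine all at once, and no compound shown pairs a plain phenyl at this place with compound 4 on everything else, so the share of each part stays open. Also open, from the compounds shown here alone, is how a pyridine ring without the oxygen, or a fluorine or a methoxy group in place of the chlorine, would behave at this place on the same background.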